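A few compounds are considered here, and "the series" means these few. Any claim that something is new, unique, unknown or untested is made for them only; others in the source may bear on it.

Measured so far:
compound 1 `CC(=O)Nc1cccc(Cn2cc(-c3ccc4cn[nH]c4c3)ccc2=O)c1` — 163 nM
compound 2 `O=c1ccc(-c2ccc3cn[nH]c3c2)cn1Cc1cccc(C(F)(F)F)c1` — 40 nM
compound 3 `O=c1ccc(-c2ccc3cn[nH]c3c2)cn1Cc1ccccc1` — 315 nM

All three share one core and differ in one place. In an assay for inhibition of MAP kinase-interacting serine/threonine-protein kinase 1 (Homo sapiens), read by luminescence and ADP-Glo, with a stated time of 2 h (on this read-out lower numbers stand for stronger inhibition and higher numbers for weaker inhibition), compound 1 stands second highest of the three: compound 3 lies within the scatter of it, while the step of a 4.1-fold lower number from compound 1 to compound 2 (0.61 log units; beyond the scatter) is beyond it. Compound 4 `CC(=O)Nc1cccc(Cn2cc(-c3ccc4c(N)n[nH]c4c3)ccc2=O)c1` is not yet measured. It differs from compound 1 by amino in place of hydrogen on an aromatic carbon. Within the data shown here, none of the measured steps bears on this change: a 4.1-fold lower number from compound 1 to compound 2 (0.61 log units; beyond the scatter), a 1.9-fold higher number from compound 1 to compound 3 (0.29 log units; within the scatter) and a 7.9-fold higher number from compound 2 to compound 3 (0.90 log units; beyond the scatter) all concern a different aromatic carbon, and no measured pair varies the fused system of two rings. No direction can therefore be inferred. Compound 4 is expected to move by a 1.0-fold lower number from compound 1 to compound 4 (0.01 log units; within the scatter). Compound 4 is estimated at 160 nM, with a range from 50 nM to 500 nM.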

Compound 4, half-maximal inhibitory concentration: 55 nM
Beside the measured number, compound 4's estimate is 2.9-fold (0.46 log units) above it; the range from low to high includes it.
By their numbers in this assay, from the lowest: compounds 2 and 4 (each within the scatter of the next); then compounds 1 and 3 (each within the scatter of the next).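

In this assay, among these compounds, amino in place of hydrogen on an aromatic carbon of the five-membered aromatic ring brings a 3.0-fold lower number from compound 1 to compound 4 (0.47 log units; beyond the scatter) and so shows that the fused system of two rings, untouched in the earlier compounds, also responds to change. The earlier steps shown here varied only a different aromatic carbon. No measurement shown here explains this step. Still open, as far as these compounds go, is whether a methyl, a hydroxyl or a longer amine chain on this carbon would act like amino, and whether amino and trifluoromethyl together would add up.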